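This account rests on a few compounds, and the source may have more. Where it says the series, first, only, none or still open, it means among the compounds named here.

Measured in a functional assay on A549 cells (Homo sapiens) for cytotoxicity, read by MTT assay, with a stated time of 48 h; a lower number here means a stronger inhibitor, a higher number a weaker inhibitor:
Compound 1 `C=C1C(=O)O[C@H]2CC3=C[C@H](C/C(C)=C/[C@@H](OC(=O)c4ccc(-c5ccccc5)cc4)[C@H]12)OC3=O`: 4600 nM.
Compound 2 `C=C1C(=O)O[C@H]2CC3=C[C@H](C/C(C)=C/[C@@H](OC(=O)/C=C/c4ccc(C(F)(F)F)cc4)[C@H]12)OC3=O`: 5900 nM.
Compound 3 `C=C1C(=O)O[C@H]2CC3=C[C@H](C/C(C)=C/[C@@H](OC(=O)CCCCBr)[C@H]12)OC3=O`: > 10000 nM.

Compound 3 stands only at > 10000 nM, which is a limit of the assay and not a number. Compound 4 `C=C1C(=O)O[C@H]2CC3=C[C@H](C/C(C)=C/[C@@H](OC(=O)CC(C)C)[C@H]12)OC3=O` has isopropyl in place of 3-bromopropyl on a saturated chain carbon bound to a carbonyl carbon. For the measured compounds named here, no measured step covers this change. The numbers that do exist, compound 1 at 4600 nM and compound 2 at 5900 nM, mark the strong end of what is expected for compound 4. The expected move in this assay is small, an at least 1.1-fold lower number from compound 3 to compound 4 (0.04 log units; that floor lies within the scatter), and toward stronger inhibition if it can be seen at all. For compound 4 the estimate is 9000 nM, with an expected range of 4000 nM to 20000 nM.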

Compound 4, half-maximal inhibitory concentration: 2500 nM
Compound 4: the middle estimate sits 3.6-fold (0.56 log units) above what was measured; the whole stated range lies above it.
By their numbers in this assay, from the lowest: compounds 4, 1 and 2 (each within the scatter of the next, the first and the last beyond it). At a limit, above all of these: compound 3.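

Compound 3 stands at a limit of the assay, not at a number: the limit of > 10000 nM in this assay, at which 1 of the 4 values shown sits.

In this assay, isopropyl in place of 3-bromopropyl on a saturated chain carbon bound to a carbonyl carbon gives an at least 4.0-fold lower number from compound 3 to compound 4 (0.60 log units; beyond the scatter), so the read-out at this place responds to a change of a small group with no ring. Compound 4 has no ring in this group, yet its value lies within the scatter of that of compound 1.

As far as these compounds go, whether the bromine, the branching or the chain length carries the step stays open, and its full size cannot be read past the limit. An unbranched propyl, a terminal amine or a carboxylic acid at this place would help separate these.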